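The compounds below may be only part of what the source reports. "The series", "measured", "known", "first", "only" and "open" are said of these compounds alone.

Measured so far in a functional assay on OVCAR-3 cells (Homo sapiens) for antiproliferative activity, read by MTT assay, with a stated time of 24 h; a lower number here means a stronger inhibitor, a higher number a weaker inhibitor:
compound 1 `O=c1[nH]cc(S(=O)(=O)Nc2cccc(-c3cn(-c4ccccc4)nn3)c2)c(=O)[nH]1` gives > 20000 nM, which is a limit of the assay and not a number.
compound 2 `O=c1[nH]cc(S(=O)(=O)Nc2cccc(-c3cn(-c4ccccc4F)nn3)c2)c(=O)[nH]1` gives 12500 nM.
compound 3 `O=c1[nH]cc(S(=O)(=O)Nc2cccc(-c3cn(-c4ccc(F)cc4)nn3)c2)c(=O)[nH]1` gives > 20000 nM, again a limit of the assay rather than a number.

Compound 3 therefore stands at the edge of what this assay reports, and it shares that position with compound 1: the limit of > 20000 nM in this assay, at which 2 of the 3 values shown sit. Only compound 2 yields a number, and the readable steps are small: an at least 1.6-fold lower number from compound 1 to compound 2 (0.20 log units; that floor lies within the scatter) and an at least 1.6-fold higher number from compound 2 to compound 3 (0.20 log units; that floor lies within the scatter), both sitting at floors that the scatter swallows, while a step that the two limits leave unreadable from compound 1 to compound 3 cannot be read at all.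

Compound 4 `O=c1[nH]cc(S(=O)(=O)Nc2cccc(-c3cn(-c4ccc(Cl)cc4)nn3)c2)c(=O)[nH]1` differs from compound 3 in one place: chloro in place of fluoro on an aromatic carbon. Among the compounds with values here, no measured step exchanges one halogen for another; the steps that exist move or add a fluoro on the same ring, and they give no sign of movement beyond the scatter. Nothing here supports a step of any clear size for the chloro entering para to a large group, so a number near the limit, or the limit itself, is expected for compound 4, with an at least 1.1-fold lower number from compound 3 to compound 4 (0.04 log units; that floor lies within the scatter) as the estimated step. For compound 4 the expected value in this assay is 18000 nM, estimated between 7000 nM and 45000 nM.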

Compound 4, half-maximal inhibitory concentration: 2040 nM
Compound 4: the middle estimate sits 8.8-fold (0.95 log units) above what was measured; measured number below the stated range.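

In this assay, the para place on the 4-fluorophenyl group proves sensitive to the identity of the halogen, which the earlier fluoro steps, all within the scatter or unreadable, gave no sign of: chloro in place of fluoro gives an at least 9.8-fold lower number from compound 3 to compound 4 (0.99 log units; beyond the scatter), and chloro in place of hydrogen at the same carbon gives an at least 9.8-fold lower number from compound 1 to compound 4 (0.99 log units; beyond the scatter). Within the data shown here, the 4-chlorophenyl group also stands clear of the only other measured number, with a 6.1-fold lower number from compound 2 to compound 4 (0.79 log units; beyond the scatter), so a halogen at this place, para to a large group, can move the result beyond the scatter when it is chloro. The step from compound 1 to compound 3 cannot be read, and the two steps to compound 4 from these compounds are floors only, since compound 1 and compound 3 each sit at a limit of the assay: the limit of > 20000 nM in this assay, at which 2 of the 4 values shown sit.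

As far as these compounds go, whether the change depends on chloro itself or would also appear with bromo, methyl or trifluoromethyl at this carbon stays open. Also open, from the compounds shown here alone, is how an amine or a carboxylic acid at the same place would read in this assay.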